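The source may hold more compounds than are shown below. What is called first, only, known or untested is meant among the compounds shown, and "the series" means these compounds.

In an assay on isolated protein for inhibition of protein kinase C delta type (Homo sapiens), read by TR-FRET, with a stated time of 2 h (a lower number here means a stronger inhibitor, a higher number a weaker inhibitor), compound 3 `CC1(C)C[C@@H](Nc2cc(NCc3cnccc3C(F)(F)F)ncc2C#N)CC[C@H]1O` gives 2400 nM, the higher of the two numbers shown, while compound 1 `N#Cc1cnc(NCc2cnccc2C(F)(F)F)cc1NC[C@H]1CC[C@H](O)CC1` gives 2000 nM, a step of a 1.2-fold higher number from compound 1 to compound 3 (0.08 log units; within the scatter). Compound 2 `N#Cc1cnc(NCc2cnccc2C(F)(F)F)cc1NCCC1CCOCC1` reaches only the limit > 10000 nM in this assay. Compound 4 `CC1(C)[C@H](Nc2cc(NCc3cnccc3C(F)(F)F)ncc2C#N)C[C@H]1C(N)=O` differs from compound 3 by 3-carbamoyl-2,2-dimethylcyclobutyl in place of 4-hydroxy-3,3-dimethylcyclohexyl on a nitrogen on an aromatic ring. For the measured compounds named here, the steps that bear on such a swap are an at least 5.0-fold higher number from compound 1 to compound 2 (0.69 log units; beyond the scatter) and an at least 4.1-fold lower number from compound 2 to compound 3 (0.61 log units; beyond the scatter), both showing that changing the ring carried on that nitrogen can move the number beyond the scatter, whereas a 1.2-fold higher number from compound 1 to compound 3 (0.08 log units; within the scatter) stayed within it. Since the donor and acceptor counts do not change, at most a modest weakening is expected, a 1.7-fold higher number from compound 3 to compound 4 (0.22 log units; within the scatter). Compound 4 is therefore estimated at 4000 nM, within a range from 1500 nM to 12000 nM.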

Compound 4, half-maximal inhibitory concentration: 900 nM
For compound 4 the middle estimate is 4.4-fold (0.65 log units) above the measured one, outside the stated range (below it).
By their numbers in this assay, from the lowest: compound 4; then compounds 1 and 3 (each within the scatter of the next). At a limit, above all of these: compound 2.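

In this assay the four-membered ring of 3-carbamoyl-2,2-dimethylcyclobutyl gives a 2.7-fold lower number from compound 3 to compound 4 (0.43 log units; beyond the scatter) and likewise a 2.2-fold lower number from compound 1 to compound 4 (0.35 log units; beyond the scatter) on the same nitrogen. Unlike the swap between compounds 1 and 3, this change moves the number beyond the scatter, and it shows that a smaller ring carrying carbamoyl instead of hydroxy can give the lowest number of the set. The largest step, an at least 11-fold lower number from compound 2 to compound 4 (1.04 log units; beyond the scatter), rests on a limit and not a number: the limit of > 10000 nM in this assay, at which 1 of the 4 values shown sits.

Ring size and the change from hydroxy to carbamoyl come together here, so the compounds shown cannot separate them. A cyclobutyl ring carrying hydroxy, or a cyclohexyl ring carrying carbamoyl or a carboxylic acid, would be needed to tell them apart.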